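Swapping the aryl arm of compound 1 for a short amino-hydroxy chain

The source may report more compounds than this note shows. Statements on the series, on what has been measured and on what is new or still open speak of the compounds shown alone.

Measured compounds and their values:
compound 1, `COc1ccc(Cn2c(=O)n(C3OC(CO)[C@@H](O)[C@H]3O)c3nc(N)nc(O)c32)cc1`, 44%
compound 2, `CC1(C)O[C@@H]2[C@H](O1)[C@@H](CO)O[C@H]2n1c(=O)n(C/C=C/c2ccccc2)c2c(O)nc(N)nc21`, 16%
compound 3, `C=CCn1c(=O)n(C2OC(CO[Si](c3ccccc3)(c3ccccc3)C(C)(C)C)[C@@H](O)[C@H]2O)c2nc(N)nc(O)c21`, 33%

The three compounds share a core and differ in the group on the chain carbon bound to an aromatic nitrogen, as well as in how the sugar part is dressed. In a functional assay on the whole organism (B cells) with Mus musculus as the target (on this read-out higher numbers stand for larger maximal responses and lower numbers for smaller maximal responses), compound 1 gives 44%, the highest of the three numbers. Compound 3 gives 33%, lower by an amount beyond the scatter, and compound 2 gives 16%, lower still and also beyond the scatter. No two of these compounds differ in only one place, so no single step can be read off among them.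

Compound 4, `NCC(O)Cn1c(=O)n(C2OC(CO)[C@@H](O)[C@H]2O)c2nc(N)nc(O)c21`, has not been measured. It differs from compound 1 in one place: 2-amino-1-hydroxyethyl in place of 4-methoxyphenyl on a saturated chain carbon bound to an aromatic nitrogen. For the measured compounds named here, with no measured pair that isolates this change, the expectation for compound 4 in this assay rests on the spread of the three numbers alone. Compound 4 is expected to fall below compound 1, by a number 14 percentage points lower from compound 1 to compound 4 (beyond the scatter), a step of moderate size beyond the scatter. The estimate for compound 4 is 30%, within a range from 15% to 45%.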

Compound 4, largest response reached (reported as maximal response), in percent of the reference or control that the assay uses: 110%
Estimate against measurement, compound 4: 80 percentage points below; the measured number lies above the stated range.
By their numbers in this assay, from the lowest: compound 2; then compound 3; then compound 1; then compound 4.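

In this assay, putting 2-amino-1-hydroxyethyl in place of 4-methoxyphenyl on a saturated chain carbon bound to an aromatic nitrogen gives a number 66 percentage points higher from compound 1 to compound 4 (beyond the scatter). For the compounds shown here, this is the first single change that can be read, and it shows that the group at this place strongly affects the maximal response and that an aromatic ring is not needed there for a high number. No measurement shown here accounts for the size of this step.

The change removes the ring and the methoxy group while adding the amino and hydroxy groups, so the compounds shown do not separate these parts. As far as these compounds go, whether the amine or the hydroxyl matters more remains open, and a 3-aminopropyl or 2-hydroxypropyl chain at this place would bear on that question.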